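Dimethylcarbamoyl in Place of the Acid of Compound 1

The source may hold more compounds than are shown below. What is called first, only, known or untested is meant among the compounds shown, and "the series" means these compounds.

Compound 1, `O=C(O)CCCc1ccc(NCc2cccc(Oc3ccccc3)c2)cc1`: 1120 nM
Compound 2, `Cc1nc(-c2ccc(C(F)(F)F)cc2)sc1CNc1ccc(/C=C/C(=O)O)cc1`: 36.3 nM
Compound 3, `Cc1nc(-c2ccc(C(F)(F)F)cc2)sc1CNc1ccc(C(C)CC(=O)O)cc1`: 58.9 nM

In a functional assay on CHO cells for agonist activity at Free fatty acid receptor 1 (Homo sapiens) (a lower number here means that less compound is needed, a higher number that more compound is needed for the effect), compound 1 gives the highest number of the three, with compound 3 and compound 2 both lower by margins beyond the scatter. Compound 4, `CN(C)C(=O)CCc1ccc(NCc2cccc(Oc3ccccc3)c2)cc1`, differs from compound 1 in one place: dimethylcarbamoyl in place of carboxymethyl on a saturated chain carbon, two bonds along the chain from an aromatic carbon. For the measured compounds named here, the only measured step, a 1.6-fold higher number from compound 2 to compound 3 (0.21 log units; within the scatter), reshapes the chain that carries the carboxymethyl but keeps that group on both sides, so it does not bear on a change in which carboxymethyl leaves. Going by the values given here, no measured pair shows such a removal. Compound 4 is nonetheless expected to need more compound, with the step of a 7.1-fold higher number from compound 1 to compound 4 (0.85 log units; beyond the scatter) expected to lie beyond the scatter. Compound 4 is estimated at 8000 nM, within a range from 2000 nM to 30000 nM.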

Compound 4, half-maximal effective concentration: 174 nM
Compound 4: middle estimate off by 46-fold (1.66 log units), on the high side, and the stated range ends above it.
By their numbers in this assay, from the lowest: compounds 2 and 3 (each within the scatter of the next); then compound 4; then compound 1.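

On a saturated chain carbon, two bonds along the chain from an aromatic carbon, dimethylcarbamoyl in place of carboxymethyl gives, in this assay, a 6.4-fold lower number from compound 1 to compound 4 (0.81 log units; beyond the scatter). On the core of compound 1, then, the carboxylic acid can leave without the number rising, and the entering group, with 0 hydrogen-bond donors, gives the lower number. No measurement at hand explains this step. Still open, from the compounds shown here alone, is how a primary carboxamide or a methyl ester would read at this place, and whether dimethylcarbamoyl on a longer chain would read the same.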